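Chalcone series: halogen for methoxy on the styryl ring

The source may report more compounds than this note shows. Statements on the series, on what has been measured and on what is new or still open speak of the compounds shown alone.

Three compounds of the series carry a measurement in a functional assay on HaCaT cells (Homo sapiens), read by fluorescence and BrdU incorporation, with a stated time of 48 h, tested at 10 uM; a lower number here means a stronger effect, a higher number a weaker effect of the compound at the concentration tested. Compound 1 `COc1cc(O)c(C(=O)/C=C/c2ccc(F)cc2)c(OC)c1` is reported in this assay as "not active" (no number reported), without a number. Compound 2 `COc1cccc(/C=C/C(=O)c2c(OC)cc(OC)cc2OC)c1` gives 19% in this assay. Compound 3 `COc1cc(O)c(C(=O)/C=C/c2ccccc2OC)c(OC)c1` gives 49% in this assay. Among the two numbers, compound 2 is the lower, and compound 3 stands above it by a gap beyond the usual scatter; compound 1 contributes no number to the comparison.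

Compound 4 `COc1cc(OC)c(C(=O)/C=C/c2ccc(Br)cc2)c(OC)c1` has not yet been measured in this assay. Relative to compound 2 the change is 4-bromophenyl in place of 3-methoxyphenyl on a double-bonded chain carbon bound to a double-bonded chain carbon. The shared core of compound 2 and compound 4 is unchanged.

Within the data shown here, no measured pair differs in exactly one place, so no step of this kind has been observed. The step from compound 2 to compound 4 is therefore estimated rather than read off, and an upward step, towards a weaker effect, of a size beyond the scatter is expected as a number 26 percentage points higher from compound 2 to compound 4 (beyond the scatter), since moving away from the substitution of compound 2 is shown by compound 3, which gives 49%. Compound 4 is expected to give about 45% in this assay, with a range from 15% to 80%.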

Compound 4, a percentage reported as activity, at one concentration (the size of the read-out at that concentration, not a potency): 24%
Beside the measured number, compound 4's estimate is 21 percentage points above it, within the range that was stated.
By their numbers in this assay, from the lowest: compounds 2 and 4 (each within the scatter of the next); then compound 3.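

In this assay, among these compounds, 4-bromophenyl in place of 3-methoxyphenyl on a double-bonded chain carbon bound to a double-bonded chain carbon gives a number 5 percentage points higher from compound 2 to compound 4 (within the scatter), the first step that can be read at a single place. The leaving group counts 1 hydrogen-bond acceptor and the entering group 0, so for this one pair the read-out at the tested concentration holds within the scatter without that acceptor, and a bromine-bearing ring serves here as well as a methoxy-bearing one. Nothing measured in the series gives a cause for this result.

The step changes the kind of substituent and its place on the ring together, so a 4-methoxyphenyl or a 3-bromophenyl group would be needed to tell these two changes apart. As far as these compounds go, how far this tolerance extends also remains open, since the shared core has so far carried only these two aryl groups in a readable step, and an aminophenyl or a carboxyphenyl group at the same place could show whether an amine or a carboxylic acid is accepted there too.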